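Swapping a Side Group on Two Related Cores

A few compounds are considered here, and "the series" means these few. Any claim that something is new, unique, unknown or untested is made for them only; others in the source may bear on it.

Measured compounds:
compound 1, `O=C(NCc1cc(Cl)ccc1-n1cnnn1)[C@@H]1CC=NN1C(=O)[C@H](O)c1ccccc1F`: 1100 nM
compound 2, `CC1(C[C@@H](O)C(=O)N2N=CC[C@H]2C(=O)NCc2cc(Cl)ccc2-n2cnnn2)CC1`: 730 nM
compound 3, `CC1(C[C@@H](O)C(=O)N2C[C@H]3C[C@H]3[C@H]2C(=O)NCc2cc(Cl)ccc2-n2cnnn2)CC1`: 500 nM

In a functional assay on a cell-free system (plasma, Homo sapiens), with a stated time of 3 min (a higher number here means a weaker inhibitor, a lower number a stronger inhibitor), compound 1 gives 1100 nM, compound 2 gives 730 nM and compound 3 gives 500 nM. Compound 3 carries the lowest number of the three, but its gap to compound 2 lies within the scatter; only its gap to compound 1 lies beyond it. The difference between the cores of compound 2 and compound 3 is not broken down here. Compound 1 differs from compound 2 by one change, (2-fluorophenyl in place of (1-methylcyclopropyl)methyl on a saturated chain carbon bound to a carbonyl carbon and an oxygen on a saturated carbon), and that change made a 1.5-fold higher number from compound 2 to compound 1 (0.18 log units; within the scatter). Compound 4, `O=C(NCc1cc(Cl)ccc1-n1cnnn1)[C@@H]1[C@@H]2C[C@@H]2CN1C(=O)[C@H](O)c1ccccc1F`, has not yet been measured; it differs from compound 3 by the same change, (2-fluorophenyl in place of (1-methylcyclopropyl)methyl on a saturated chain carbon bound to a carbonyl carbon and an oxygen on a saturated carbon). Because a 1.5-fold higher number from compound 2 to compound 1 (0.18 log units; within the scatter) lay within the scatter, the step from compound 3 to compound 4 is expected to be of similar size, a 1.5-fold higher number from compound 3 to compound 4 (0.18 log units; within the scatter). For compound 4 in this assay the estimate is 750 nM, with a likely range from 350 nM to 1600 nM.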

Compound 4, half-maximal inhibitory concentration: 580 nM
Estimate against measurement, compound 4: 1.3-fold (0.11 log units) above, within the range that was stated.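

In this assay, putting 2-fluorophenyl in place of (1-methylcyclopropyl)methyl gives a 1.2-fold higher number from compound 3 to compound 4 (0.06 log units; within the scatter) on the second core, and the comparison with the first core reads as follows: the same change on two cores in this assay, a 1.5-fold higher number (0.18 log units; within the scatter) from compound 2 to compound 1 and a 1.2-fold higher number (0.06 log units; within the scatter) from compound 3 to compound 4, 1.3-fold (0.11 log units) apart, within the scatter of two such steps. The change therefore behaves alike on the two cores shown, and knowing the step on one core would have been a fair guide to the step on the other. This does not show that the change moves the number in a real way on either core, since each step lies within the scatter, and two cores are too few to support a rule for other cores in this series.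

The compounds shown leave open what other groups would do at this same place, such as an unsubstituted phenyl, an amine or a longer chain. They also leave open whether the two cores would still match for a change that gives a step beyond the scatter.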